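A few compounds are considered here, and "the series" means these few. Any claim that something is new, unique, unknown or untested is made for them only; others in the source may bear on it.

Measured so far in a functional assay on HT-29 cells (Homo sapiens) for cytotoxicity, read by MTT assay, with a stated time of 72 h; on this read-out lower numbers stand for higher toxicity in this test and higher numbers for lower toxicity in this test:

Compound 1, `CCCCC[Se]c1nc(NCc2ccc(SC)cc2)c2ccccc2n1`. In this assay compound 1 gives > 100000 nM, which is a limit of the assay and not a number.

Compound 2, `CSc1ccc(CNc2nc(SC)nc3ccccc23)cc1`. In this assay compound 2 gives > 100000 nM, again a limit of the assay and not a number.

Going by the values given here, compound 2 therefore stands at the limit only; no numerical cytotoxicity is known for it, and the one further value is likewise a limit.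

The next compound is compound 3, `CSc1ccc(CNc2nc([Se]C)nc3ccccc23)cc1`. It differs from compound 2 in one place: a group of 2 heavy atoms (1 carbon, 1 selenium; no ring) in place of a group of 2 heavy atoms (1 carbon, 1 sulfur; no ring), on an aromatic carbon. The methylsulfanyl group that leaves carries one hydrogen-bond acceptor, the entering selenium group none.

Among the compounds with values here, only one measured step exists, from compound 1 to compound 2: a step that the two limits leave unreadable from compound 1 to compound 2. Because (the limit of > 100000 nM in this assay, at which 2 of the 2 values shown sit), that step has neither a readable size nor a readable direction, and it gives no guide for the exchange of sulfur for selenium at this position. Nothing else in the series bears on the step to compound 3.

The expected step from compound 2 to compound 3 in this assay is therefore a number no higher from compound 2 to compound 3 (the limit leaves the size open), with no change beyond the scatter and a high chance that compound 3 is again reported only as a limit. For compound 3 the estimated value in this assay is 100000 nM, with a range from 30000 nM to 300000 nM.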

Compound 3, concentration lethal to 50% of the cells: > 100000 nM
Compound 3 ended at the assay's limit (the forecaster's own chance of this, stated with the estimate: 80%); the middle value lies on the limit itself.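

In this assay compound 3 gives > 100000 nM, a limit of the assay and not a number. No new step can be read among compound 1, compound 2 and compound 3: the limit of > 100000 nM in this assay, at which 3 of the 3 values shown sit.

The compounds shown leave open whether the exchange of sulfur for selenium, or the chain length on selenium, has any bearing on the read-out in this assay.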